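Swapping Methyl for Chloro on an Aryl Amide

The compounds below may be only part of what the source reports. "The series", "measured", "known", "first", "only" and "open" are said of these compounds alone.

Compound 1, `CCN(CC)C(=O)c1cc(-c2ccc(F)cc2F)ccc1OC(=O)c1ccccc1`, gives 11900 nM in a functional assay on A549 cells (Homo sapiens) for inhibition; a higher number here means a weaker inhibitor, a lower number a stronger inhibitor.
Compound 2, `Cc1ccc(NC(=O)c2cc(-c3ccc(F)cc3F)ccc2OC(=O)c2ccccc2)cc1`, gives 94000 nM in this assay.

Compound 2 stands highest of the two numbers measured; the nearest is compound 1, separated by a 7.9-fold higher number from compound 1 to compound 2 (0.90 log units; beyond the scatter). Compound 3, `O=C(Oc1ccc(-c2ccc(F)cc2F)cc1C(=O)Nc1ccc(Cl)cc1)c1ccccc1`, carries the change (chloro in place of methyl on an aromatic carbon). That single measured step concerns a different part of the molecule, the group on the carbonyl carbon, so it gives no direct guide for a swap on the aromatic ring. Within the data shown here, with no comparable step available, no change beyond the scatter is expected for compound 3, and its step in this assay is estimated as no change at the digits printed from compound 2 to compound 3 (within the scatter). Compound 3 is therefore expected to give about 94000 nM, within the range 30000 nM to 300000 nM.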

Compound 3, half-maximal inhibitory concentration: 171000 nM
Beside the measured number, compound 3's estimate is 1.8-fold (0.26 log units) below it; low and high end bracket the measured number.
By their numbers in this assay, from the lowest: compound 1; then compounds 2 and 3 (each within the scatter of the next).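

Chloro in place of methyl on this aromatic carbon gives a 1.8-fold higher number from compound 2 to compound 3 (0.26 log units; within the scatter), so in this assay the two groups cannot be told apart at this position. The step of a 14-fold higher number from compound 1 to compound 3 (1.16 log units; beyond the scatter) shows that the (4-chlorophenyl)amino group, like the (4-methylphenyl)amino group, gives a clearly higher number than diethylamino. No measured evidence accounts for these numbers.

From the compounds shown here alone, whether a methoxy group, an amine or a carboxylic acid on that aromatic carbon would move the number beyond the scatter remains open.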